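The source may report more compounds than this note shows. Statements on the series, on what has been measured and on what is new or still open speak of the compounds shown alone.

Of the compounds shown here, two have been measured in an assay for binding affinity to Indoleamine 2,3-dioxygenase 1 (Homo sapiens), read by spectrophotometry, with a stated time of 30 min; a lower number here means tighter binding, a higher number weaker binding. Compound 1 `C#Cc1cc(C(O)Cc2ccccc2)c2cn[nH]c2c1` gives 1300 nM. Among the compounds with values here, compound 2 `OC(Cc1ccccc1)c1cc(-c2ccccc2)cc2[nH]ncc12` gives 53000 nM, the highest of the two numbers; its only neighbour is compound 1, and a 41-fold higher number from compound 1 to compound 2 (1.61 log units; beyond the scatter). Compound 3 `OC(Cc1ccccc1)c1cc(C2CC2)cc2[nH]ncc12` is not yet measured; it differs from compound 2 by cyclopropyl in place of phenyl on an aromatic carbon. Within the data shown here, the one measured step that bears on this site, a 41-fold higher number from compound 1 to compound 2 (1.61 log units; beyond the scatter), shows that the number moves strongly with the group there; no step to cyclopropyl has been measured, so the size of the coming change rests on that single step alone. Because compound 1 with ethynyl at this site gives 1300 nM, a lower number than compound 2 is expected for compound 3, though not a full return. The estimate for compound 3 is 8000 nM, with a range of 2000 nM to 30000 nM. For compound 3 this expectation means a 6.6-fold lower number from compound 2 to compound 3 (0.82 log units; beyond the scatter).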

Compound 3, dissociation constant: 1200 nM
The estimate for compound 3 lay 6.7-fold (0.82 log units) above the measured number, outside the stated range (below it).
By their numbers in this assay, from the lowest: compounds 3 and 1 (each within the scatter of the next); then compound 2.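

Cyclopropyl in place of phenyl on this aromatic carbon produces a large change in this assay (a 44-fold lower number from compound 2 to compound 3 (1.65 log units; beyond the scatter)), so the weak binding of compound 2 goes with phenyl and is not a general result of replacing ethynyl. Cyclopropyl and ethynyl are not separated at this position (a 1.1-fold lower number from compound 1 to compound 3 (0.03 log units; within the scatter)), showing that a non-aromatic three-membered carbon ring and an ethynyl group can both be carried here with no difference beyond the scatter; among the three groups shown, only phenyl stands apart. No available measurement explains why the number moves with the group at this position.

The compounds shown leave open how a methyl, a longer alkyl chain, an amine or a carboxylic acid would behave at this aromatic carbon. They also leave open whether the same ranking of groups holds when the group of 9 heavy atoms is changed.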